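Working notes: from compound 2 to compound 3

A few compounds are considered here, and "the series" means these few. Any claim that something is new, unique, unknown or untested is made for them only; others in the source may bear on it.

- compound 1 (`Fc1ccc(CSc2nnc(-c3cnccn3)s2)cc1`) gives (10100 nM)
- compound 2 (`Clc1cccc(CSc2nnc(-c3cnccn3)n2-c2ccccc2)c1`) gives (19600 nM)

Both values come from a single test (a functional assay on HepG2 cells (Homo sapiens) for antiproliferative activity, read by MTT assay, with a stated time of 48 h; on this read-out lower numbers stand for stronger inhibition and higher numbers for weaker inhibition). Compound 2 and compound 1 lie within the scatter of each other, so the two cannot be ranked. For the measured compounds named here, the series offers no measured step between compounds that differ in one place, so no direct guide exists for the change considered here.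

Compound 3 (`Clc1ccc(CSc2nnc(-c3cnccn3)n2-c2ccccc2)cc1`) differs from compound 2 by one change (4-chlorophenyl in place of 3-chlorophenyl on a saturated chain carbon bound to a sulfur): 4-chlorophenyl in place of 3-chlorophenyl on a saturated chain carbon bound to a sulfur. In this test (this assay), no step beyond the scatter is expected, in either direction. The expected step is small (a 1.2-fold lower number from compound 2 to compound 3 (0.09 log units; within the scatter)). Compound 3 is estimated at 16000 nM (expected range 7000 nM to 35000 nM).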

Compound 3, half-maximal inhibitory concentration: 15300 nM
Beside the measured number, compound 3's estimate is 1.0-fold (0.02 log units) above it; the measured number falls inside the stated range.
By their numbers in this assay, from the lowest: compounds 1, 3 and 2 (each within the scatter of the next).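

In this assay, the exchange of 3-chlorophenyl for 4-chlorophenyl on a saturated chain carbon bound to a sulfur gives the series its first step between compounds that differ in one place (a 1.3-fold lower number from compound 2 to compound 3 (0.11 log units; within the scatter)). For the compounds shown here, at this position, the two chlorophenyl groups therefore cannot be told apart on this read-out, which the earlier compounds alone could not show. No supporting data are available to explain this result.

Going by these compounds, with only these two chlorophenyl groups compared here, it remains open whether a carboxylic acid, an amine or a longer chain in place of the chlorophenyl group would give a step beyond the scatter. On these data alone, it is also open whether the same exchange would read the same way on the core of compound 1.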